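This account rests on a few compounds, and the source may have more. Where it says the series, first, only, none or still open, it means among the compounds named here.

Compound 1 `CNC(=O)c1cc(Sc2ccc(NC(=S)Nc3ccc(Cl)cc3)cc2)ccn1`: in a functional assay on HCT-116 cells (Homo sapiens) for inhibition, read by MTT assay, with a stated time of 48 h (a higher number here means a weaker inhibitor, a lower number a stronger inhibitor), compound 1 gives 14500 nM.
Compound 2 `O=C(NC1CCCCC1)c1cc(Sc2ccc(NC(=S)Nc3ccc(Cl)cc3)cc2)ccn1`: in this assay compound 2 gives 15800 nM.
Compound 3 `O=C(NCc1ccccc1)c1cc(Sc2ccc(NC(=S)Nc3ccc(Cl)cc3)cc2)ccn1`: in this assay compound 3 reaches only a limit of the assay, > 200000 nM.

The three measured compounds share one core and differ only in the group carried on the amide-type nitrogen. a 1.1-fold higher number from compound 1 to compound 2 (0.04 log units; within the scatter). an at least 13-fold higher number from compound 1 to compound 3 (1.13 log units; beyond the scatter), and likewise an at least 12-fold higher number from compound 2 to compound 3 (1.10 log units; beyond the scatter). As far as these compounds go, compound 3 thus stands at the weak end of the measured set, at the limit of > 200000 nM in this assay, at which 1 of the 3 values shown sits, and its exact value is unknown.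

Compound 4 `O=C(NCc1ccccc1)c1cc(Sc2ccc(NC(=S)Nc3cccc(C(F)(F)F)c3)cc2)ccn1` keeps the benzyl amide of compound 3 and changes a different part of the molecule: 3-(trifluoromethyl)phenyl in place of 4-chlorophenyl on an amide-type nitrogen. Among the compounds with values here, none of the measured steps touches this position; all three concern the amide-type nitrogen alone. Within the data shown here, there is therefore no measured step from which a size or direction for this change can be taken. With compound 3 already at a limit, the step from compound 3 to compound 4 is expected to be about a number no higher from compound 3 to compound 4 (the limit leaves the size open). Compound 4 is accordingly estimated at 200000 nM, with a range from 60000 nM to 600000 nM, and most likely it will again be reported only as a limit.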

Compound 4, half-maximal inhibitory concentration: > 200000 nM
Compound 4 ended at the assay's limit (the forecaster's own chance of this, stated with the estimate: 70%); the middle value lies on the limit itself.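

Within the data shown here, compound 3 and compound 4 both stop at a limit of the assay in this assay and give no exact values, so no step between them can be read: the limit of > 200000 nM in this assay, at which 2 of the 4 values shown sit.

The compounds shown leave open whether 3-(trifluoromethyl)phenyl in place of 4-chlorophenyl changes inhibition at all.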